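The source may hold more compounds than are shown below. What is called first, only, known or untested is meant among the compounds shown, and "the series" means these compounds.

Going by the values given here, in an assay on HEK293 cells for displacement of a labelled ligand from NPC1-like intracellular cholesterol transporter 1 (Homo sapiens) (a lower number here means a stronger inhibitor, a higher number a weaker inhibitor), compound 3 `CC(C)(C)c1ccc(C(=O)N2CCC3(CC2)C(=O)N(CC(=O)NCCCCN)CN3c2ccccc2)cc1` gives 14500 nM, the highest of the three numbers measured so far. Compound 1 `CC(C)(C)c1ccc(C(=O)N2CCC3(CC2)C(=O)N(CC(=O)NCCN)CN3c2ccccc2)cc1` gives 7000 nM, and compound 2 `CC1(C)CC(OC(=O)CN2CN(c3ccccc3)C3(CCN(C(=O)c4ccc(C(C)(C)C)cc4)CC3)C2=O)CC(C)(C)N1` gives 1300 nM. Both measured steps end at compound 3: a 2.1-fold higher number from compound 1 to compound 3 (0.32 log units; beyond the scatter) and an 11-fold higher number from compound 2 to compound 3 (1.05 log units; beyond the scatter). The (2,2,6,6-tetramethylpiperidin-4-yl)oxy group of compound 2 thus goes with the lowest number, and the (4-aminobutyl)amino group of compound 3 with the highest.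

Compound 4 `CCOC(=O)C1CCCN(C(=O)CN2CN(c3ccccc3)C3(CCN(C(=O)c4ccc(C(C)(C)C)cc4)CC3)C2=O)C1` differs from compound 3 in one place: 3-(ethoxycarbonyl)piperidin-1-yl in place of (4-aminobutyl)amino on a carbonyl carbon. As in compound 2, a group carrying a six-membered ring takes the place of the open chain on that carbonyl carbon, so the step of an 11-fold higher number from compound 2 to compound 3 (1.05 log units; beyond the scatter) read in reverse bears on it most, with a 2.1-fold higher number from compound 1 to compound 3 (0.32 log units; beyond the scatter) pointing the same way. Among the compounds with values here, the entering group is not the one of compound 2, so only part of that span is expected. The expected step in this assay is a 4.1-fold lower number from compound 3 to compound 4 (0.62 log units; beyond the scatter). Compound 4 is expected to give 3500 nM, with a range from 900 nM to 13000 nM.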

Compound 4, half-maximal inhibitory concentration: 8200 nM
Compound 4: middle estimate off by 2.3-fold (0.37 log units), on the low side; the range from low to high includes it.
By their numbers in this assay, from the lowest: compound 2; then compounds 1, 4 and 3 (each within the scatter of the next, the first and the last beyond it).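

Placing 3-(ethoxycarbonyl)piperidin-1-yl on this carbonyl carbon in place of (4-aminobutyl)amino gives a 1.8-fold lower number from compound 3 to compound 4 (0.25 log units; within the scatter), so a six-membered ring at this place does not by itself bring the low number of compound 2. That gap remains, with a 6.3-fold higher number from compound 2 to compound 4 (0.80 log units; beyond the scatter), while the comparison with the short-chain compound gives a 1.2-fold higher number from compound 1 to compound 4 (0.07 log units; within the scatter). The entering group has no hydrogen-bond donors and the leaving group has two, yet this exchange stays within the scatter.

Still open, going by these compounds, is whether the low number of compound 2 goes with its oxygen link to the carbonyl carbon or with its ring, which a plain piperidin-4-yl group or a carboxylic acid in place of the ethoxycarbonyl group could help separate. No measurement at hand explains any of these differences.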